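A few compounds are considered here, and "the series" means these few. Any claim that something is new, unique, unknown or untested is made for them only; others in the source may bear on it.

Measured so far in an assay on isolated protein for inhibition of DNA topoisomerase 1 (Homo sapiens), with a stated time of 30 min, tested at 100 uM; a higher number here means a stronger effect of the compound at the concentration tested, a lower number a weaker effect:
Compound 1, `Oc1ccc(-c2cc(-c3ccc(Cl)cc3)nc(-c3cccnc3)c2)cc1`, gives 18.8%.
Compound 2, `Oc1ccc(-c2cc(-c3cccnc3)nc(-c3cccc(Cl)c3)c2)cc1`, gives 55.2%.
Compound 3, `Oc1ccc(-c2cc(-c3ccc(Cl)cc3)nc(-c3ccco3)c2)cc1`, gives 15.8%.

Compound 4, `Oc1ccc(-c2cc(-c3cccc(Cl)c3)nc(-c3ccco3)c2)cc1`, has not yet been measured. It is made from compound 3 by a single rearrangement, (3-chlorophenyl in place of 4-chlorophenyl on an aromatic carbon).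

The same change has been measured once before, from compound 1 to compound 2, where it gave a number 36.4 percentage points higher from compound 1 to compound 2 (beyond the scatter) in this assay. The two cores are not identical, though: compound 3 differs from compound 1 by furan-2-yl in place of pyridin-3-yl on an aromatic carbon, and that swap made a number 3 percentage points lower from compound 1 to compound 3 (within the scatter). So the surroundings of the change are not the same word for word: in compound 1 the site is meta to a pyridin-3-yl group, in compound 3 it is meta to a furan-2-yl group. The change is therefore the same kind of change, not the same.

For the measured compounds named here, with only one precedent, the uncertainty is wide. Going by the values given here, the step is expected to be of similar direction, estimated at about a number 29.2 percentage points higher from compound 3 to compound 4 (beyond the scatter) in this assay, because the one earlier instance of this change gave a number 36.4 percentage points higher from compound 1 to compound 2 (beyond the scatter). Compound 4 is therefore estimated at 45%, expected to fall between 20% and 65%.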

Compound 4, a percentage reported as inhibition, at one concentration (the size of the read-out at that concentration, not a potency): 25.5%
Compound 4: the middle estimate sits 19.5 percentage points above what was measured; the range from low to high includes it.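

On the core of compound 3, 3-chlorophenyl in place of 4-chlorophenyl gives a number 9.7 percentage points higher from compound 3 to compound 4 (within the scatter) in this assay, so the large rise seen on the core of compound 1 is not repeated at that size: the same change on two cores in this assay, a number 36.4 percentage points higher (beyond the scatter) from compound 1 to compound 2 and a number 9.7 percentage points higher (within the scatter) from compound 3 to compound 4, 26.7 percentage points apart, beyond the scatter of two such steps. Read the other way, furan-2-yl in place of pyridin-3-yl gives a number 29.7 percentage points lower from compound 2 to compound 4 (beyond the scatter), whereas the same swap made no difference beyond the scatter when the 4-chlorophenyl group was present: the same change on two cores in this assay, a number 3 percentage points lower (within the scatter) from compound 1 to compound 3 and a number 29.7 percentage points lower (beyond the scatter) from compound 2 to compound 4, 26.7 percentage points apart, beyond the scatter of two such steps. The two changes therefore do not simply add up in these four compounds, and the result of one depends on which group is present at the other site, but this set shows neither why that is so nor whether it holds beyond these compounds.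

The compounds shown leave open how this pairing behaves with a methoxy group or an amine in place of the chlorine, or with thiophen-2-yl in place of furan-2-yl. They also leave open whether the 4-hydroxyphenyl group matters to the pattern, since it is the same in all four compounds.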